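The source may report more compounds than this note shows. Statements on the series, on what has been measured and on what is new or still open speak of the compounds shown alone.

Measured so far:
compound 1 `CC(C)CC/N=C(\NC#N)Nc1cccnc1` — 20 mg/kg in a functional assay on the whole organism (blood, strain Wistar-Okamoto) with Rattus norvegicus as the target, with a stated time of 5 days; on this read-out higher numbers stand for an effect only at larger amounts of compound and lower numbers for an effect already at smaller amounts
compound 2 `CCCCC(CC)C/N=C(\NC#N)Nc1cccnc1` — > 50 mg/kg, a limit of this assay, not a number

Compound 1 carries the only number shown in this assay. For compound 2 only a limit is reported, (the limit of > 50 mg/kg in this assay, at which 1 of the 2 values shown sits). Among the compounds with values here, no step between two measured compounds that differ in one place is available, so no measured step size can be cited. Compound 3 `N#CN/C(=N\Cc1ccco1)Nc1cccnc1` comes from compound 1 by furan-2-yl in place of isobutyl on a saturated chain carbon bound to a double-bonded nitrogen. Without a measured step to lean on, the step of no change at the digits printed from compound 1 to compound 3 (within the scatter) is expected to stay within the usual scatter, in no fixed direction. For compound 3 the estimate is 20 mg/kg, with a range from 8 mg/kg to 50 mg/kg.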

Compound 3, minimum effective dose: 20 mg/kg
For compound 3 middle estimate and measured number coincide at the digits printed; low and high end bracket the measured number.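

In this assay, furan-2-yl in place of isobutyl gives no change at the digits printed from compound 1 to compound 3 (within the scatter) and so shows that this place, on a saturated chain carbon bound to a double-bonded nitrogen, holds a five-membered aromatic ring as well as an open branched chain. The earlier compounds shown here carried only open chains here. No measured property bears on why the two groups read alike.

Open, from the compounds shown here alone, is how a phenyl ring, a thiophene, an amine or a carboxylic acid at this place would read. Also open, going by these compounds, is whether any group here gives an effect at smaller doses.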